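The source may hold more compounds than are shown below. What is called first, only, known or untested is meant among the compounds shown, and "the series" means these compounds.

Measured compounds:
compound 1, `Cn1c(-c2ccc(NC(=O)CSc3nc4cc(Cl)ccc4o3)cc2)nc(-c2ccccc2)c1-c1ccccc1`, 69.1%
compound 2, `Cc1nnc(SCC(=O)Nc2ccc(-c3nc(-c4ccccc4)c(-c4ccccc4)n3C)cc2)s1`, 85.2%

Among the measured compounds shown here, in a functional assay on MCF7 cells (Homo sapiens) for cytotoxicity, read by MTT assay, with a stated time of 24 h, tested at 80 ug/mL (on this read-out lower numbers stand for a weaker effect and higher numbers for a stronger effect at the one concentration tested), compound 2 stands highest of the two numbers known; its nearest neighbour is compound 1, and the step of a number 16.1 percentage points higher from compound 1 to compound 2 (beyond the scatter) lies beyond the scatter. For the measured compounds named here, that step replaces one group on the sulfur with another, and it is the only measured step that touches the same position. Compound 3, `Cn1ccnc1SCC(=O)Nc1ccc(-c2nc(-c3ccccc3)c(-c3ccccc3)n2C)cc1`, is not yet measured. It differs from compound 2 in the same place: 1-methyl-1H-imidazol-2-yl in place of 5-methyl-1,3,4-thiadiazol-2-yl on a sulfur. Going by the values given here, the single measured step shows that exchanging the group on this sulfur can move the read-out by a modest amount, but the group entering in compound 3 is not the one that entered in compound 2, so that step is only a loose guide. A step of similar size in either direction would not be surprising, and a step within the scatter is equally plausible. On that basis compound 3 is expected to give 78%, within a range from 60% to 92%, which means an expected step of a number 7.2 percentage points lower from compound 2 to compound 3 (within the scatter) that may well stay within the usual scatter.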

Compound 3, a percentage reported as activity, at one concentration (the size of the read-out at that concentration, not a potency): 64%
Estimate against measurement, compound 3: 14 percentage points above, and the stated range covers the measured number.
By their numbers in this assay, from the lowest: compounds 3 and 1 (each within the scatter of the next); then compound 2.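

In this assay, the change on the sulfur from 5-methyl-1,3,4-thiadiazol-2-yl to 1-methyl-1H-imidazol-2-yl gives a number 21.2 percentage points lower from compound 2 to compound 3 (beyond the scatter), so even two single five-membered aromatic rings with the same count of heavy atoms are not interchangeable at this place; the group that leaves has a ring sulfur and the group that enters has none. The other new step, a number 5.1 percentage points lower from compound 1 to compound 3 (within the scatter), shows that 1-methyl-1H-imidazol-2-yl and the fused 5-chloro-1,3-benzoxazol-2-yl cannot be told apart in this assay, so among these three compounds only compound 2 stands apart, and the higher number belongs to its 5-methyl-1,3,4-thiadiazol-2-yl rather than to the sulfur-linked heteroaryl groups in general. Nothing available explains why these groups differ in this way.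

The compounds shown leave open whether the ring sulfur matters or whether the higher number rests on the whole 5-methyl-1,3,4-thiadiazol-2-yl, a question that a 5-methyl-1,3,4-oxadiazol-2-yl on the same sulfur would address. They also leave open how a group without an aromatic ring, such as an amine-bearing chain, would read at this place, and, with a single concentration, how the three compounds compare in potency.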